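This account rests on a few compounds, and the source may have more. Where it says the series, first, only, none or still open, it means among the compounds named here.

Measured so far in a functional assay on HEK293 cells (Homo sapiens) for cytotoxicity; on this read-out higher numbers stand for lower toxicity in this test and lower numbers for higher toxicity in this test:
- compound 1 `COc1ccc([C@H]2CC(=O)N(c3cccc(NCCCc4ccccc4)c3)C2)cc1OC1CCCC1`: > 10000 nM, a limit
- compound 2 `COc1ccc([C@H]2CC(=O)N(c3cccc(NC(=O)C(C)=O)c3)C2)cc1OC1CCCC1`: > 10000 nM, a limit
- compound 3 `COc1ccc([C@H]2CC(=O)N(c3cccc(NS(=O)(=O)c4cccc(OC(F)(F)F)c4)c3)C2)cc1OC1CCCC1`: > 10000 nM, a limit

Compound 3 gives no exact number in this assay, only > 10000 nM, which is a limit. It shares this position with the other two compounds, as the data show (the limit of > 10000 nM in this assay, at which 3 of the 3 values shown sit).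

The next compound, compound 4 `COc1ccc([C@H]2CC(=O)N(c3cccc(NS(=O)(=O)c4cccc(Cl)c4C)c3)C2)cc1OC1CCCC1`, keeps the shared core and changes one group. It carries 3-chloro-2-methylphenyl in place of 3-(trifluoromethoxy)phenyl on a sulfonyl sulfur.

For the measured compounds named here, only one measured step bears on this, and only loosely. It is a step that the two limits leave unreadable from compound 1 to compound 2, so it gives no size to carry over. What remains is that compound 1, compound 2 and compound 3 carry different groups, yet none has left the limit. No step beyond the scatter is therefore expected, and no direction can be foreseen. The estimated step is a number no higher from compound 3 to compound 4 (the limit leaves the size open). A reading at the limit is the likeliest outcome. For compound 4 the expected value is 10000 nM, with an estimated range from 5000 nM to 20000 nM.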

Compound 4, half-maximal cytotoxic concentration: > 10000 nM
Compound 4: only a limit was reported; the forecaster's own chance of this, stated with the estimate: 90%; the middle value lies on the limit itself.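

In this assay compound 4 gives only a limit, as do compound 1, compound 2 and compound 3, so none of the steps to compound 4 can be read: the limit of > 10000 nM in this assay, at which 4 of the 4 values shown sit.

The compounds shown leave open whether any of these groups changes the half-maximal cytotoxic concentration, and by how much.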